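This account rests on a few compounds, and the source may have more. Where it says the series, first, only, none or still open, it means among the compounds named here.

Measured compounds:
compound 1 `O=C(CCc1cn(Cc2ccc3oc(-c4ccccc4)cc(=O)c3c2)nn1)Nc1ccc(F)cc1`: 15600 nM
compound 2 `Cc1ccc(C(=O)NCc2cn(Cc3ccc4oc(-c5ccc(Cl)cc5)cc(=O)c4c3)nn2)cc1`: 32900 nM

Both compounds were tested in an assay on isolated protein for inhibition of Amine oxidase [flavin-containing] B (Homo sapiens), read by fluorescence and spectrophotometry; on this read-out higher numbers stand for weaker inhibition and lower numbers for stronger inhibition. Compound 1 gives 15600 nM, and compound 2 gives 32900 nM. Of the two numbers, that of compound 2 is the higher one, and the gap between the two values lies beyond the usual scatter of this kind of measurement, so compound 2 is the weaker inhibitor of the pair.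

Compound 3 `Cc1ccc(NC(=O)CCc2cn(Cc3ccc4oc(-c5ccc(Cl)cc5)cc(=O)c4c3)nn2)cc1` shares the core of compound 2 and differs from it in one place: ((4-methylphenyl)carbamoyl)methyl in place of ((4-methylphenyl)carbonyl)amino on a saturated chain carbon bound to an aromatic carbon. For the measured compounds named here, no measured pair shows the effect of this kind of change on its own. Compound 1, which carries the same type of chain as compound 3, gives the lower of the two numbers, which suggests a modest downward step. For compound 3 in this assay a value of 18000 nM is expected, within a range from 6000 nM to 50000 nM, and the expected step is a 1.8-fold lower number from compound 2 to compound 3 (0.26 log units; within the scatter).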

Compound 3, half-maximal inhibitory concentration: 32900 nM
Compound 3: middle estimate off by 1.8-fold (0.26 log units), on the low side; measured number inside the range.
By their numbers in this assay, from the lowest: compound 1; then compounds 2 and 3 (each within the scatter of the next).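

In this assay, placing ((4-methylphenyl)carbamoyl)methyl in place of ((4-methylphenyl)carbonyl)amino on a saturated chain carbon bound to an aromatic carbon gives no change at the digits printed from compound 2 to compound 3 (within the scatter). For the compounds shown here, this is the first direct reading of this change on its own: the two groups, each with one six-membered aromatic ring of carbon only, cannot be told apart at this place on this read-out. No measurement at hand accounts for this result.

Still open, going by these compounds, is whether a group of a different kind at this place, such as a simple amine or a carboxylic acid, would move the number. Also open, on these data alone, is whether the same swap would give the same result with a methoxy group in place of the methyl on the aromatic ring of these groups.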